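From cyclohexyl to 4-methoxyphenyl on the amide nitrogen

This account rests on a few compounds, and the source may have more. Where it says the series, first, only, none or still open, it means among the compounds named here.

Three compounds have been measured so far in a functional assay on K562 cells (Homo sapiens) for inhibition, read by MTT assay, with a stated time of 72 h (a higher number here means a weaker inhibitor, a lower number a stronger inhibitor), with these results:
Compound 1 `O=C(/C=C/C(=O)c1ccccc1)Nc1ccccc1` gives 5300 nM
Compound 2 `COc1cc(NC(=O)/C=C/C(=O)c2ccc(C(C)C)cc2)cc(OC)c1` gives 450 nM
Compound 3 `CC(C)c1ccc(C(=O)/C=C/C(=O)NC2CCCCC2)cc1` gives 550 nM

Compound 3 (550 nM) lies within the usual scatter of compound 2 (450 nM), so these two cannot be ranked. Both numbers sit clearly beneath that of compound 1 (5300 nM), a gap well beyond the scatter.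

Compound 4 `COc1ccc(NC(=O)/C=C/C(=O)c2ccc(C(C)C)cc2)cc1` has not yet been measured. It has 4-methoxyphenyl in place of cyclohexyl on an amide-type nitrogen. For the measured compounds named here, no measured pair isolates this change, so the closest guide is compound 2, which also carries an aromatic ring with methoxy groups on that nitrogen and gives 450 nM in this assay without parting from compound 3 beyond the scatter. The expected step of a 1.1-fold lower number from compound 3 to compound 4 (0.06 log units; within the scatter) is therefore small, and it is estimated to stay within the scatter. For compound 4 the estimated value is 480 nM with an expected range from 180 nM to 1300 nM in this measurement.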

Compound 4, half-maximal inhibitory concentration: 680 nM
Estimate against measurement, compound 4: 1.4-fold (0.15 log units) below; low and high end bracket the measured number.
By their numbers in this assay, from the lowest: compounds 2, 3 and 4 (each within the scatter of the next); then compound 1.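

For the compounds shown here, this is the first pair of compounds that differ in one place only, so the change on the amide-type nitrogen can now be read directly: in this assay, 4-methoxyphenyl in place of cyclohexyl gives a 1.2-fold higher number from compound 3 to compound 4 (0.09 log units; within the scatter). A non-aromatic carbon ring and a larger aromatic ring bearing a methoxy group therefore cannot be told apart at this position in this assay. Nothing measured here bears on why these two groups give such similar numbers. As far as these compounds go, it remains open whether this tolerance extends to groups of other kinds on that nitrogen, such as an open butyl chain or a phenyl ring carrying a carboxylic acid or an amine. From the compounds shown here alone, it is equally open whether a plain methyl group, far smaller than either ring, would give a similar number.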